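Shifting the Methyl on the Aryl Urea of Compound 1

A few compounds are considered here, and "the series" means these few. Any claim that something is new, unique, unknown or untested is made for them only; others in the source may bear on it.

Measured compounds:
compound 1 `Cc1ccccc1NC(=O)NCC1(c2ccccc2)CCCCC1`: 640 nM
compound 2 `O=C(NCC1(c2ccccc2)CCCCC1)Nc1ccccc1C(F)(F)F`: 200 nM

Both compounds were tested in an assay on microsomes from intestine for inhibition of acyl-CoA:cholesterol acyltransferase (Oryctolagus cuniculus); a lower number here means a stronger inhibitor, a higher number a weaker inhibitor. Compound 1 gives 640 nM, and compound 2 gives 200 nM. Among the two, compound 1 carries the higher number; its nearest neighbour is compound 2, and the only measured step, a 3.2-fold lower number from compound 1 to compound 2 (0.51 log units; beyond the scatter), comes from trifluoromethyl in place of methyl on an aromatic carbon.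

Compound 3 `Cc1ccc(NC(=O)NCC2(c3ccccc3)CCCCC2)cc1` has not yet been measured. It differs from compound 1 by 4-methylphenyl in place of 2-methylphenyl on an amide-type nitrogen: the two share the same atoms, joined differently, so the methyl stays but the 2-methylphenyl becomes a 4-methylphenyl on the amide-type nitrogen.

Among the measured compounds shown here, no measured step bears on this change. The step from compound 1 to compound 2 swaps the group itself rather than moving the methyl, so it offers no guide to direction. With nothing to point either way, compound 3 is expected to land close to compound 1, with the step of no change at the digits printed from compound 1 to compound 3 (within the scatter) expected to stay within the scatter. Compound 3 is therefore estimated at 640 nM, within a range from 220 nM to 1900 nM.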

Compound 3, half-maximal inhibitory concentration: 4500 nM
Compound 3: middle estimate off by 7.0-fold (0.85 log units), on the low side; measured number above the stated range.
By their numbers in this assay, from the lowest: compound 2; then compound 1; then compound 3.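

Moving the methyl, with the atoms unchanged, gives a 7.0-fold higher number from compound 1 to compound 3 (0.85 log units; beyond the scatter) in this assay, so the number depends on where the methyl sits on the phenyl group and not only on which group is present. Compound 1 and compound 2 had shown only that replacing the group itself changes the number, whereas this pair shows that the 2-methylphenyl on the amide-type nitrogen of compound 1 gives a lower number than the 4-methylphenyl of compound 3, with the shared core left untouched. The data at hand offer no explanation of why the 4-methylphenyl carries the higher number.

The compounds shown leave open whether other groups on the phenyl, such as a chlorine atom, a methoxy group or an ethyl group, would respond to the same move as methyl does, and whether trifluoromethyl would follow methyl in the same direction. They also leave open how a 3-methylphenyl on the same nitrogen would compare with the 2-methylphenyl and 4-methylphenyl, and whether an unsubstituted phenyl would stand closer to compound 1 or to compound 3.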